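Halogen Swap on an Aryl Urea: Bromo to Iodo

The compounds below may be only part of what the source reports. "The series", "measured", "known", "first", "only" and "open" are said of these compounds alone.

Compound 1 `C[C@@H](NC(=O)Nc1ccccc1C(C)(C)C)c1ccccc1` gives 95% in an ADME assay on the whole organism with Oryza sativa as the target, tested at 1 uM; on this read-out higher numbers stand for a weaker effect at the one concentration tested and lower numbers for a stronger effect.
Compound 2 `C[C@@H](NC(=O)Nc1ccccc1F)c1ccccc1` gives 95% in this assay.
Compound 3 `C[C@@H](NC(=O)Nc1ccccc1Br)c1ccccc1` gives 100% in this assay.

The three compounds share one core and differ only in the group on the aromatic ring. Compound 3 shows the highest of the three numbers, yet the steps of a number 5 percentage points higher from compound 1 to compound 3 (within the scatter) and a number 5 percentage points higher from compound 2 to compound 3 (within the scatter) both lie within the scatter, so the three stand level. Compound 4 `C[C@@H](NC(=O)Nc1ccccc1I)c1ccccc1` differs from compound 3 by iodo in place of bromo on an aromatic carbon. The earlier halogen exchange a number 5 percentage points higher from compound 2 to compound 3 (within the scatter) and the other replacements no change at the digits printed from compound 1 to compound 2 (within the scatter) and a number 5 percentage points higher from compound 1 to compound 3 (within the scatter) all stayed within the scatter, so no step beyond the scatter is expected here either: a number 2 percentage points lower from compound 3 to compound 4 (within the scatter) is the estimated change. Compound 4 is therefore expected to give about 98%, between 88% and 105%.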

Compound 4, a percentage reported as activity, at one concentration (the size of the read-out at that concentration, not a potency): 100%
Estimate against measurement, compound 4: 2 percentage points below; measured number inside the range.
By their numbers in this assay, from the lowest: compounds 1, 2, 3 and 4 (each within the scatter of the next).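

Iodo on this aromatic carbon behaves like the groups before it in this assay: the change gives no change at the digits printed from compound 3 to compound 4 (within the scatter), and the wider comparisons give a number 5 percentage points higher from compound 2 to compound 4 (within the scatter) and a number 5 percentage points higher from compound 1 to compound 4 (within the scatter). Four groups at this one place, three halogens and tert-butyl, therefore stand level, with no step beyond the scatter. Nothing available accounts for this flat result. Still open, as far as these compounds go, is whether an amine or a carboxylic acid at this place would move the number beyond the scatter.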